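A few compounds are considered here, and "the series" means these few. Any claim that something is new, unique, unknown or untested is made for them only; others in the source may bear on it.

Measured compounds:
- compound 1, `CC1(c2ccccc2)CC(=O)N(CC(=O)N2CCN(c3ccccc3F)CC2)C1=O`: "not active" (no number reported)
- compound 2, `CC1(c2ccccc2)CC(=O)N(CC(=O)N2CCN(c3cccc(Cl)c3)CC2)C1=O`: 300 mg/kg

Both were tested in a functional assay on the whole organism (strain CD-1) with Mus musculus as the target, in the maximal electroshock model, with a stated time of 2 h; on this read-out higher numbers stand for an effect only at larger amounts of compound and lower numbers for an effect already at smaller amounts. For compound 1 the result is "not active" (no number reported), so no number stands behind it. Among the compounds with values here, compound 2 reached 300 mg/kg, which is the only number in this set; the other entry carries no number to compare it with, so no step between measured compounds can be given.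

Compound 3, `CC1(c2ccccc2)CC(=O)N(CC(=O)N2CCN(c3ccccc3)CC2)C1=O`, has not yet been measured. It differs from compound 2 in one place: hydrogen in place of chloro on an aromatic carbon. The shared core is the same, only the 3-chlorophenyl becomes phenyl.

Nothing in the data shows what this change does, so the expectation rests on compound 2 alone. The step is expected to be small, within the usual scatter, with compound 3 estimated at 400 mg/kg, in a range from 200 mg/kg to 1000 mg/kg, which corresponds to an expected 1.3-fold higher number from compound 2 to compound 3 (0.12 log units; within the scatter).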

Compound 3, minimum effective dose: "not active" (no number reported)
Nothing numeric was reported for compound 3; there is nothing to compare the estimate with.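

Within the data shown here, compound 3, like compound 1, carries no number in this assay, so no step from compound 2 to compound 3 can be read. The compounds shown leave open how much the change from 3-chlorophenyl to phenyl matters. No other data here bear on this result.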